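The source may report more compounds than this note shows. Statements on the series, on what has been measured and on what is new or still open speak of the compounds shown alone.

Measured compounds:
compound 1 `COc1cc(-c2cc(/C=C/C(=O)c3ccc(Cl)c(Cl)c3)[nH]n2)cc(OC)c1OC` — 101%
compound 2 `COc1ccc(C(=O)/C=C/c2cc(-c3cc(OC)c(OC)c(OC)c3)n[nH]2)cc1` — 89%

In a functional assay on K562 cells (Homo sapiens) for cytotoxicity, read by sulforhodamine B assay, with a stated time of 48 h, tested at 1 uM (a lower number here means a stronger effect, a higher number a weaker effect of the compound at the concentration tested), compound 2 gives 89%, the lower of the two numbers, and compound 1 gives 101%. Within the data shown here, the only step between them, a number 12 percentage points lower from compound 1 to compound 2 (beyond the scatter), was modest but beyond the scatter. Compound 3 `COc1cc(-c2cc(/C=C/C(=O)c3ccc(F)c(F)c3)[nH]n2)cc(OC)c1OC` has not been measured in this assay. It differs from compound 2 in one place: 3,4-difluorophenyl in place of 4-methoxyphenyl on a carbonyl carbon. The step from compound 1 to compound 2 bears on this change, since it ran from a dihalogenated phenyl to 4-methoxyphenyl on the carbonyl carbon and lowered the number; the present change removes the 4-methoxyphenyl again in favour of a dihalogenated phenyl. Compound 3 is therefore expected to sit somewhat higher than compound 2, a step of a number 8 percentage points higher from compound 2 to compound 3 (within the scatter), modest in size. The estimate for compound 3 in this assay is 97%, with a range from 85% to 108%.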

Compound 3, a percentage reported as activity, at one concentration (the size of the read-out at that concentration, not a potency): 102%
The estimate for compound 3 lay 5 percentage points below the measured number, within the range that was stated.
By their numbers in this assay, from the lowest: compound 2; then compounds 1 and 3 (each within the scatter of the next).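

In this assay, replacing the 3,4-dichlorophenyl on the carbonyl carbon with 3,4-difluorophenyl gives a number 1 percentage points higher from compound 1 to compound 3 (within the scatter), so the two dihalogenated phenyl groups cannot be told apart at this position. Replacing the 4-methoxyphenyl with 3,4-difluorophenyl gives a number 13 percentage points higher from compound 2 to compound 3 (beyond the scatter), so compound 2 now stands apart from two dihalogenated partners rather than one, although the difference remains modest. No measured evidence accounts for this difference.

Whether the lower number of compound 2 is specific to the 4-methoxyphenyl remains open, since an unsubstituted phenyl, a 4-ethoxyphenyl or a 4-aminophenyl on the same carbonyl carbon does not appear among these compounds. From the compounds shown here alone, it is also open how a carboxylic acid on that phenyl would read in this assay.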